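The source may report more compounds than this note shows. Statements on the series, on what has been measured and on what is new or still open speak of the compounds shown alone.

Among the compounds with values here, compound 2 `Cc1cc(C)c(NC(=O)N(Cc2ccc(-c3ccn(C)n3)cc2)C2CCCCCC2)c(C)c1` is one of two compounds measured in an assay on microsomes from intestine for inhibition of acyl-CoA:cholesterol acyltransferase (Oryctolagus cuniculus) (on this read-out lower numbers stand for stronger inhibition and higher numbers for weaker inhibition), where compound 2 gives 44 nM. Within the data shown here, its only measured neighbour is compound 1 `Cc1cc(C)c(NC(=O)N(Cc2ccc(-c3ccccn3)cc2)C2CCCCCC2)c(C)c1`, for which this assay gives 33 nM; the single measured step, a 1.3-fold higher number from compound 1 to compound 2 (0.12 log units; within the scatter), shows that exchanging one small aromatic heterocycle for another at the same position left the result within the scatter.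

Compound 3 `Cc1cc(C)c(NC(=O)N(Cc2ccc(-c3ccnn3C)cc2)C2CCCCCC2)c(C)c1` is not yet measured. It differs from compound 2 only in the change (1-methyl-1H-pyrazol-5-yl in place of 1-methyl-1H-pyrazol-3-yl on an aromatic carbon), so the same atoms are joined differently and the heterocycle is attached through another of its carbons. Among the measured compounds shown here, the step from compound 1 to compound 2 is the one measurement that bears on this kind of exchange, and it was small. On that basis no step beyond the scatter is expected in this assay from compound 2 to compound 3, though a single precedent gives little certainty about direction. Compound 3 is therefore estimated at 45 nM, with a range from 18 nM to 110 nM, corresponding to an expected step of a 1.0-fold higher number from compound 2 to compound 3 (0.01 log units; within the scatter).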

Compound 3, half-maximal inhibitory concentration: 24 nM
For compound 3 the middle estimate is 1.9-fold (0.27 log units) above the measured one; low and high end bracket the measured number.
By their numbers in this assay, from the lowest: compounds 3, 1 and 2 (each within the scatter of the next).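

Within the data shown here, the exchange of 1-methyl-1H-pyrazol-3-yl for 1-methyl-1H-pyrazol-5-yl gives a 1.8-fold lower number from compound 2 to compound 3 (0.26 log units; within the scatter) in this assay and is the first reading of what happens when the same heterocycle is joined through another of its carbons. Set against the pyridin-2-yl group of compound 1, the 1-methyl-1H-pyrazol-5-yl group gives a 1.4-fold lower number from compound 1 to compound 3 (0.14 log units; within the scatter) and so also stays within the scatter. At this place, on an aromatic carbon para to a large group, neither the choice among these three groups nor the carbon through which the pyrazole is attached separates the compounds on this read-out. Nothing shown here offers an explanation for these numbers.

Going by these compounds, how far this tolerance reaches remains open, for instance whether an amine or a carboxylic acid at the same place would keep the result within the scatter of these three compounds. Also open, on these data alone, is what the methyl group on the pyrazole nitrogen contributes, which a pyrazole with a hydrogen or a longer chain on that nitrogen would address.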